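A few compounds are considered here, and "the series" means these few. Any claim that something is new, unique, unknown or untested is made for them only; others in the source may bear on it.

In an ADME assay on HepG2 cells (Homo sapiens) for cytotoxicity, read by MTT assay, with a stated time of 48 h (on this read-out lower numbers stand for higher toxicity in this test and higher numbers for lower toxicity in this test), compound 1 `C#CCN(c1nc(-c2ccccc2)no1)C1CCCCC1` gives 109 ug/mL, the higher of the two actual numbers here. Compound 3 `CC(=O)OC[C@H]1O[C@H](OC[C@@H](Cn2cc(CN(c3nc(-c4ccc(Cl)cc4)no3)C3CCCCC3)nn2)OC(C)=O)C=C[C@@H]1OC(C)=O`, a much larger molecule, gives 46.9 ug/mL. Compound 2 `CC(=O)OC[C@H]1O[C@H](OC[C@@H](Cn2cc(CN(c3nc(-c4ccc([N+](=O)[O-])cc4)no3)C3CCCCC3)nn2)OC(C)=O)C=C[C@@H]1OC(C)=O`, similarly large, gives > 200 ug/mL, which is a limit of the assay. Compound 4 `C#CCN(c1nc(-c2ccc([N+](=O)[O-])cc2)no1)C1CCCCC1` is compound 1 with nitro in place of hydrogen on an aromatic carbon. Among the measured compounds shown here, no measured step makes this exact change. The closest is chloro in place of nitro, an at least 4.2-fold lower number from compound 2 to compound 3 (0.62 log units; beyond the scatter), which suggests that nitro need not lower the number. No step beyond the scatter is firmly expected, and the estimated change is a 1.4-fold higher number from compound 1 to compound 4 (0.14 log units; within the scatter). Compound 4 is expected at 150 ug/mL, with an estimated range of 65 ug/mL to 320 ug/mL.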

Compound 4, half-maximal cytotoxic concentration: 43.7 ug/mL
Estimate against measurement, compound 4: 3.4-fold (0.54 log units) above; measured number below the stated range.
By their numbers in this assay, from the lowest: compounds 4 and 3 (each within the scatter of the next); then compound 1. At a limit, above all of these: compound 2.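

Nitro on this aromatic carbon, para to a large group, does not keep the number high: in this assay, the change gives a 2.5-fold lower number from compound 1 to compound 4 (0.40 log units; beyond the scatter). The earlier step, an at least 4.2-fold lower number from compound 2 to compound 3 (0.62 log units; beyond the scatter), left the nitro-bearing compound 2 on the higher side, so nitro does not read the same way in compounds 1 and 4 as in compounds 2 and 3. That earlier step has no exact size: the limit of > 200 ug/mL in this assay, at which 1 of the 4 values shown sits.

Still open, on these data alone, is how an amine or a methoxy group on this carbon would read, and whether chloro would lower the number on the core of compound 1.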